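Dihydropyridine aryl swap: difluorophenyl to methylsulfanylphenyl

A few compounds are considered here, and "the series" means these few. Any claim that something is new, unique, unknown or untested is made for them only; others in the source may bear on it.

Measured:
compound 1 `COC(=O)C1=C(C)NC(C)=C(C(=O)OCC2CC2)C1c1cccc([N+](=O)[O-])c1` — 21 nM
compound 2 `CCOC(=O)C1=C(C)NC(C)=C(C(=O)OCC)C1c1cccc(F)c1F` — 10 nM

In a functional assay on HEK293 cells for antagonist activity at Voltage-dependent L-type calcium channel subunit alpha-1D (Rattus norvegicus), read by FLIPR (a lower number here means a stronger inhibitor, a higher number a weaker inhibitor), compound 2 gives 10 nM, the lowest of the two numbers; compound 1 gives 21 nM, a gap beyond the scatter. Compound 3 `CCOC(=O)C1=C(C)NC(C)=C(C(=O)OCC)C1c1ccccc1SC` differs from compound 2 by 2-(methylsulfanyl)phenyl in place of 2,3-difluorophenyl on a saturated ring carbon. For the measured compounds named here, no step between measured compounds isolates this change, so the expectation rests on compound 2 alone. A modest loss is expected, the step from a 2.0-fold higher number from compound 2 to compound 3 (0.30 log units; within the scatter) staying near the scatter. Compound 3 is estimated at 20 nM, within 5 nM to 80 nM.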

Compound 3, half-maximal inhibitory concentration: 15 nM
Compound 3: the middle estimate sits 1.3-fold (0.12 log units) above what was measured; the range from low to high includes it.
By their numbers in this assay, from the lowest: compounds 2, 3 and 1 (each within the scatter of the next, the first and the last beyond it).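

In this assay the step is a 1.5-fold higher number from compound 2 to compound 3 (0.18 log units; within the scatter) and shows that, on this saturated ring carbon, 2-(methylsulfanyl)phenyl and 2,3-difluorophenyl cannot be told apart. The position therefore takes a sulfur-bearing aryl group as well as a difluorinated one, with the number staying in the low nanomolar range. Nothing available bears on why the two groups read alike.

Open, as far as these compounds go, is whether a longer chain on the sulfur, such as ethylsulfanyl, would read the same. Also open, from the compounds shown here alone, is how a phenyl group carrying an amine or a carboxylic acid would read at this carbon.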